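A few compounds are considered here, and "the series" means these few. Any claim that something is new, unique, unknown or untested is made for them only; others in the source may bear on it.

Measured so far in an ADME assay on Huh7.5.1 cells (Homo sapiens) for cytotoxicity, read by ATP content, with a stated time of 48 h; a higher number here means that more compound is tolerated, a lower number that less compound is tolerated: compound 1 `Cc1cc(C)c(-c2nc(CN3CCC(C(=O)NCCCN4C[C@H](C)C[C@H](C)C4)CC3)c(C)o2)c(C)c1` gives 6570 nM; compound 2 `CC[C@@H]1C[C@H](CC)CN(CCCNC(=O)C2CCN(Cc3nc(-c4ccccc4C)oc3C)CC2)C1` gives 3470 nM; compound 3 `Cc1oc(-c2c(Br)cccc2Br)nc1CN1CCC(C(=O)NCCCN2C[C@H](C)C[C@H](C)C2)CC1` gives 6500 nM.

Compound 2 stands within the usual scatter of both compound 1 and compound 3, so the three numbers cannot be told apart. Compound 4 `Cc1ccccc1-c1nc(CN2CCC(C(=O)NCCN3C[C@H](C)C[C@H](C)C3)CC2)c(C)o1` arises from compound 2 by one change: 3,5-dimethylpiperidin-1-yl in place of (3,5-diethylpiperidin-1-yl)methyl on a saturated chain carbon, two bonds along the chain from an amide-type nitrogen. Within the data shown here, the only measured step, a 1.0-fold lower number from compound 1 to compound 3 (0.00 log units; within the scatter), concerns the aromatic ring and not the chain or the piperidine, so no measured step bears on this change. With nothing to point either way, no step beyond the scatter is expected in this assay, and the expected step is a 1.0-fold higher number from compound 2 to compound 4 (0.00 log units; within the scatter). Compound 4 is therefore estimated at 3500 nM, with a range from 1500 nM to 8000 nM.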

Compound 4, half-maximal cytotoxic concentration: 24400 nM
For compound 4 the middle estimate is 7.0-fold (0.84 log units) below the measured one; the measured number lies above the stated range.
By their numbers in this assay, from the lowest: compounds 2, 3 and 1 (each within the scatter of the next); then compound 4.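

In this assay, among these compounds, the change to 3,5-dimethylpiperidin-1-yl gives a 7.0-fold higher number from compound 2 to compound 4 (0.85 log units; beyond the scatter) and so moves the number beyond the scatter, which the one earlier step, on the aromatic ring, did not do. Nothing measured here explains this step. The change both shortens the chain and replaces the ethyl groups on the piperidine with methyl groups, so the compounds shown cannot separate these two parts. Going by these compounds, how a longer chain, an unsubstituted piperidine or a morpholine would behave at this position stays open.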